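Trifluoromethyl in Place of Nitro on the Aryl Hydrazone

The compounds below may be only part of what the source reports. "The series", "measured", "known", "first", "only" and "open" are said of these compounds alone.

compound 1 `Cc1c(C(=O)N/N=C/c2ccc(N(C)C)cc2)no[n+]1[O-]`: 129000 nM
compound 2 `Cc1c(C(=O)N/N=C/c2ccccc2)no[n+]1[O-]`: a limit, > 400000 nM
compound 3 `Cc1c(C(=O)N/N=C/c2ccc([N+](=O)[O-])cc2)no[n+]1[O-]`: a limit, > 300000 nM

The three measured compounds share one core and differ only in the group on the aromatic ring. In an ADME assay on J774.1 cells (Mus musculus) for cytotoxicity, read by MTT assay, with a stated time of 48 h (a lower number here means a stronger inhibitor, a higher number a weaker inhibitor), compound 1 gives 129000 nM. For compound 2 only a limit is known, > 400000 nM. Compound 3 likewise gives only a limit, > 300000 nM. Two of the three numbers shown are thus limits (the limit of > 300000 nM in this assay, at which 1 of the 3 values shown sits, and (the limit of > 400000 nM in this assay, at which 1 of the 3 values shown sits)), so compound 3 stands among them with no exact figure. Between the measured compounds there is an at least 2.3-fold higher number from compound 1 to compound 3 (0.36 log units; beyond the scatter), while a step that the two limits leave unreadable from compound 2 to compound 3.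

Compound 4 `Cc1c(C(=O)N/N=C/c2ccc(C(F)(F)F)cc2)no[n+]1[O-]` differs from compound 3 by trifluoromethyl in place of nitro on an aromatic carbon. Within the data shown here, none of the measured steps involves a trifluoromethyl; those that touch the nitro are only loosely sized by the two limits. In this assay compound 4 is therefore expected to show a number no higher from compound 3 to compound 4 (the limit leaves the size open), nothing beyond the scatter. The estimate for compound 4 in this assay is 300000 nM, with an expected range from 100000 nM to 1000000 nM.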

Compound 4, half-maximal inhibitory concentration: > 400000 nM
Compound 4: a limit, no number (the forecaster's own chance of this, stated with the estimate: 60%); middle value at least 1.3-fold (0.12 log units) away from the limit.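

In this assay compound 4 gives only a limit, > 400000 nM, and this is the limit it shares with one other compound: the limit of > 400000 nM in this assay, at which 2 of the 4 values shown sit.
Trifluoromethyl in place of dimethylamino on this aromatic carbon gives an at least 3.1-fold higher number from compound 1 to compound 4 (0.49 log units; beyond the scatter), so a third group now stands apart from dimethylamino, and compound 1 remains the only one of the four with an exact figure. The steps among compound 2, compound 3 and compound 4 cannot be read, as both ends of each are limits.

Where these three compounds truly lie remains open, and so does whether the lower number of compound 1 belongs to dimethylamino alone. A plain amino group or a carboxylic acid on the same aromatic carbon could show whether other groups also bring an exact figure.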